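The compounds below may be only part of what the source reports. "The series", "measured", "known", "first", "only" and "open" are said of these compounds alone.

Among the compounds with values here, compound 1 `CCCCCCCCCCCCCCCCCC(=O)Nc1nnc(S[C@@H]2O[C@H](COC(C)=O)[C@H](OC(C)=O)[C@H](OC(C)=O)[C@H]2OC(C)=O)s1` gives 97500 nM in a functional assay on HeLa cells (Homo sapiens) for cytotoxicity, read by MTT assay, with a stated time of 24 h (a lower number here means a stronger inhibitor, a higher number a weaker inhibitor), the highest of the three numbers so far. Compound 2 `CCCCCCCC(=O)Nc1nnc(S[C@@H]2O[C@H](CO)[C@H](O)[C@H](O)[C@H]2O)s1` gives 50800 nM, within the scatter of compound 1, while compound 3 `CCCCCCCC/C=C\CCCCCCCC(=O)Nc1nnc(S[C@@H]2O[C@H](CO)[C@H](O)[C@H](O)[C@H]2O)s1` gives 8800 nM, well beyond it. Within the data shown here, the only single-change step measured is a 5.8-fold lower number from compound 2 to compound 3 (0.76 log units; beyond the scatter), where a longer acyl chain brought the number down. Compound 4 `CCCCCC(=O)Nc1nnc(S[C@@H]2O[C@H](COC(C)=O)[C@H](OC(C)=O)[C@H](OC(C)=O)[C@H]2OC(C)=O)s1` goes the other way: hydrogen in place of dodecyl on a saturated chain carbon, five bonds along the chain from a carbonyl carbon. Among the measured compounds shown here, no measured step shares this exact change, but the chain-lengthening step from compound 2 to compound 3 suggests that chain-shortening should raise the number, so compound 4 is expected to sit above compound 1 by roughly a 2.1-fold higher number from compound 1 to compound 4 (0.31 log units; beyond the scatter), possibly beyond the top of this assay. The estimate for compound 4 is 200000 nM, in the range 80000 nM to 600000 nM.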

Compound 4, half-maximal inhibitory concentration: 19800 nM
For compound 4 the middle estimate is 10-fold (1.00 log units) above the measured one; measured number outside the range, below it.
By their numbers in this assay, from the lowest: compound 3; then compound 4; then compounds 2 and 1 (each within the scatter of the next).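

In this assay, hydrogen in place of dodecyl, five bonds along the chain from a carbonyl carbon, gives a 4.9-fold lower number from compound 1 to compound 4 (0.69 log units; beyond the scatter) and so shows that a shorter acyl chain need not raise the number. This runs opposite to a 5.8-fold lower number from compound 2 to compound 3 (0.76 log units; beyond the scatter) where the chain grows on the free hydroxyl sugar, so no single chain-length trend covers compounds 1, 2, 3 and 4. Nothing at hand explains the opposite directions.

Still open, from the compounds shown here alone, is whether chain length acts the same way with acetyl esters and with free hydroxyls. Also open, going by these compounds, is how an amine or a carboxylic acid on the acyl chain would shift the number.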